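The source may hold more compounds than are shown below. What is called first, only, known or untested is meant among the compounds shown, and "the series" means these compounds.

Measured in a functional assay on MDA-MB-435 cells (Homo sapiens) for antiproliferative activity, read by sulforhodamine B assay, with a stated time of 72 h; on this read-out lower numbers stand for stronger inhibition and higher numbers for weaker inhibition:
- compound 1 (`COc1ccc(NC(=S)NNc2nncc3ccccc23)cc1`) gives 88 nM
- compound 2 (`Fc1ccc(Nc2nncc3ccccc23)cc1`) gives 4 nM

Of these two, compound 2 has the lower number (4 nM), and its gap to compound 1 (88 nM) lies beyond the scatter. The two structures differ in more than one place, so this gap cannot be assigned to any single change.

The next compound is compound 3 (`N#Cc1ccc(Nc2nncc3ccccc23)cc1`). It keeps the core of compound 2, with cyano in place of fluoro on an aromatic carbon, para to a large group: cyano in place of fluoro on an aromatic carbon.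

Going by the values given here, no measured pair covers this exchange, so the expectation is a judgement with a wide margin. In this assay a modest step toward a higher number is expected, slightly beyond the scatter. Starting from compound 2 at 4 nM, the expectation allows more room upward than downward. The expected step is a 2.5-fold higher number from compound 2 to compound 3 (0.40 log units; beyond the scatter). For compound 3 the estimated value is 10 nM, with an expected range of 2 nM to 60 nM.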

Compound 3, half-maximal inhibitory concentration: 2 nM
For compound 3 the middle estimate is 5.0-fold (0.70 log units) above the measured one; low and high end bracket the measured number.
By their numbers in this assay, from the lowest: compounds 3 and 2 (each within the scatter of the next); then compound 1.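

In this assay, the exchange of fluoro for cyano on an aromatic carbon, para to a large group, amounts to a 2.0-fold lower number from compound 2 to compound 3 (0.30 log units; within the scatter). This position therefore takes cyano, with two heavy atoms, a triple bond and a hydrogen-bond acceptor, in place of a single fluorine without a difference that stands out from the scatter, and the two groups cannot be ranked here. Going by these compounds alone, compound 2 and compound 3 form the first pair that differ in one place, which the gap between compound 1 and compound 2 could not provide, but no measurement at hand accounts for how closely the two numbers agree.

On these data alone, it remains open whether an amine, a carboxylic acid or a longer alkyl chain at this position would stay as close to compound 2 as cyano does, since both groups compared here carry no hydrogen-bond donor and only one or two heavy atoms. Within the data shown here, also open is how much of the gap to compound 1 belongs to its sulfur-containing linker and how much to its methoxy group, as no single-place pair separates the two.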